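A few compounds are considered here, and "the series" means these few. Any claim that something is new, unique, unknown or untested is made for them only; others in the source may bear on it.

Of the compounds shown here, three sharing one core have been measured in an assay on isolated protein with adenosine receptor A3 (Homo sapiens) as the target, tested at 10 uM; on this read-out higher numbers stand for more inhibition at the one concentration tested (going by the name of the read-out) and lower numbers for less inhibition. Compound 1 `Nc1sc2c(c1C(=O)c1cccc3ccccc13)CCC2` gives 0%. Compound 2 `Nc1sc2c(c1C(=O)c1cccc3ccccc13)CCCC2` gives 34.5%. Compound 3 `Nc1sc2c(c1C(=O)c1ccc(Cl)c3ccccc13)CCCC2` gives 30.5%, the second highest of the three numbers; its nearest neighbour is compound 2, and the gap between them is within the scatter, while compound 1 lies far lower, beyond the scatter. Among the compounds with values here, the one measured step between close neighbours, a number 4 percentage points lower from compound 2 to compound 3 (within the scatter), came with chloro in place of hydrogen and stayed within the scatter.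

Compound 4 `Nc1sc2c(c1C(=O)c1ccc(Br)c3ccccc13)CCCC2` has not yet been measured in this assay. It differs from compound 3 by bromo in place of chloro on an aromatic carbon. Within the data shown here, no measured step exchanges one halogen for another; the nearest guide is the step of a number 4 percentage points lower from compound 2 to compound 3 (within the scatter), which was small, so no step beyond the scatter is expected for compound 4 in this assay. The step of a number 1.5 percentage points higher from compound 3 to compound 4 (within the scatter) is therefore expected to be small, in either direction. Compound 4 is estimated to give 32% in this assay, within a range from 14% to 50%.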

Compound 4, a percentage reported as inhibition, at one concentration (the size of the read-out at that concentration, not a potency): 48.5%
Estimate against measurement, compound 4: 16.5 percentage points below, within the range that was stated.
By their numbers in this assay, from the lowest: compound 1; then compounds 3 and 2 (each within the scatter of the next); then compound 4.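

In this assay the position para to a large group turns out to respond to the choice of halogen, a distinction the earlier step from hydrogen to chloro could not reveal: bromo in place of chloro gave a number 18 percentage points higher from compound 3 to compound 4 (beyond the scatter) and so separated two groups that might have been expected to behave alike. Bromo in place of hydrogen likewise gave a number 14 percentage points higher from compound 2 to compound 4 (beyond the scatter), so among the groups shown at this position only bromo moves the number beyond the scatter, with chloro as the exception to any general halogen trend. Nothing available here explains the difference between the two halogens.

On these data alone, whether iodo, fluoro, methoxy or a nitrile at this position would follow bromo or chloro remains open. So does whether bromo would bring any gain on the core of compound 1.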